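This account rests on a few compounds, and the source may have more. Where it says the series, first, only, none or still open, it means among the compounds named here.

The measured compounds and their values:

Compound 1, `COc1ccc(C(=O)/C=C/c2ccc(OC)c(OC)c2OC)c2c1C=CC(C)(C)O2`: in a functional assay on K562 cells (Homo sapiens) for antiproliferative activity, read by MTT assay, with a stated time of 24 h (on this read-out lower numbers stand for stronger inhibition and higher numbers for weaker inhibition), compound 1 gives > 10000 nM, which is a limit of the assay and not a number.
Compound 2, `COc1ccc(C(=O)/C=C/c2ccsc2)c2c1C=CC(C)(C)O2`: in this assay compound 2 gives > 10000 nM, also a limit.
Compound 3, `COc1cc(/C=C/C(=O)c2ccc(OC)c3c2OC(C)(C)C=C3)cc(OC)c1O`: in this assay compound 3 gives > 10000 nM, again a limit.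

Compound 2 therefore stands where every compound shown stands, at the limit of > 10000 nM in this assay, at which 3 of the 3 values shown sit. Among the measured compounds shown here, no compound here has a measured number in this assay, and no two of them differ in only one place, so no measured step exists against which a change could be weighed.

Compound 4, `COc1ccc(C(=O)/C=C/c2cc(Cl)ccc2O)c2c1C=CC(C)(C)O2`, differs from compound 2 by 5-chloro-2-hydroxyphenyl in place of thiophen-3-yl on a double-bonded chain carbon bound to a double-bonded chain carbon. Nothing in the shown results speaks for or against this exchange, since compound 2 itself is known only as a limit. The expected step from compound 2 to compound 4 is therefore a step that the limit leaves unreadable from compound 2 to compound 4, which is to say no change that the data can establish. Compound 4 is estimated at 15000 nM, with a range from 3000 nM to 60000 nM, and it is expected most likely to be reported as a limit as well.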

Compound 4, half-maximal inhibitory concentration: 5510 nM
For compound 4 the middle estimate is 2.7-fold (0.43 log units) above the measured one; low and high end bracket the measured number.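

In this assay compound 4 gives 5510 nM, the only measured number among the compounds shown, so a group at this place on a double-bonded chain carbon bound to a double-bonded chain carbon can bring the series within reach of a reading. Putting 5-chloro-2-hydroxyphenyl in place of thiophen-3-yl gives an at least 1.8-fold lower number from compound 2 to compound 4 (0.25 log units; that floor lies within the scatter), so the size of this change is known only as a floor. Compound 4 alone leaves the common limit: the limit of > 10000 nM in this assay, at which 3 of the 4 values shown sit.

The compounds shown do not separate the chlorine from the hydroxyl of the 5-chloro-2-hydroxyphenyl group, so it stays open which of them, if either, accounts for the step. On these data alone, it also stays open how a phenyl ring carrying an amine or a carboxylic acid would read at this place.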